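Aryl substituent swap and Vero cell viability: working notes

The source may hold more compounds than are shown below. What is called first, only, known or untested is meant among the compounds shown, and "the series" means these compounds.

Measured so far:
compound 1 `O=C1CSC(c2cccc(O)c2)N1CCN1CCCCC1` — 100%
compound 2 `O=C1CSC(c2ccc([N+](=O)[O-])cc2)N1CCN1CCCCC1` — 100%

In an ADME assay on Vero cells (Chlorocebus sabaeus) for cytotoxicity, read by neutral red uptake, tested at 49 ug/mL (a higher number here means a weaker effect of the compound at the concentration tested, a lower number a stronger effect), compound 1 gives 100%. In this assay compound 2 gives 100%, level with compound 1 at the digits shown and within the scatter; nothing separates the two on this read-out.

Compound 3 `Cc1ccc(C2SCC(=O)N2CCN2CCCCC2)cc1` differs from compound 2 by methyl in place of nitro on an aromatic carbon. Going by the values given here, no measured pair shows a change of this kind, so the expected step of no change at the digits printed from compound 2 to compound 3 (within the scatter) is none beyond the scatter, given that compound 2 already sits at 100%. Compound 3 is expected to give 100% in this assay, with a range from 85% to 100%.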

Compound 3, a percentage reported as activity, at one concentration (the size of the read-out at that concentration, not a potency): 100%
The estimate for compound 3 equals the measured number at the digits printed; low and high end bracket the measured number.
By their numbers in this assay, from the lowest: compounds 1, 2 and 3 (each within the scatter of the next).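

Methyl in place of nitro on an aromatic carbon gives no change at the digits printed from compound 2 to compound 3 (within the scatter) in this assay and thus provides the first measured step at this position, one that does not separate the two groups. With 4-methylphenyl in place of 3-hydroxyphenyl on a saturated ring carbon, the read-out shows no change at the digits printed from compound 1 to compound 3 (within the scatter) as well, so all three aryl groups on the shared core stand level. No available evidence bears on why the read-out stays level. On these data alone, whether an amine or a carboxylic acid on this aromatic carbon would lower the read-out remains open. As far as these compounds go, the result at any other concentration also remains open.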